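The source may report more compounds than this note shows. Statements on the series, on what has been measured and on what is new or still open speak of the compounds shown alone.

Measured compounds, with their growth inhibition in a functional assay on K562 cells (Homo sapiens) for antiproliferative activity, read by CCK-8 assay, with a stated time of 72 h; a lower number here means a stronger inhibitor of growth, a higher number a weaker inhibitor of growth:

compound 1 `CCCCNS(=O)(=O)c1ccc(Nc2ncc3c(n2)N(C2CCCC2)[C@H](CC)C(=O)N3C)cc1`: 412 nM
compound 2 `CCCCNS(=O)(=O)c1ccc(Nc2ncc3c(n2)N(c2ccn(C)n2)C(CC)C(=O)N3C)cc1`: 4240 nM
compound 3 `CC[C@@H]1C(=O)N(C)c2cnc(Nc3ccc(S(N)(=O)=O)cc3)nc2N1C1CCCC1`: 470 nM

Compound 1 and compound 3 share one core and differ in a single place, (hydrogen in place of butyl on a sulfonamide nitrogen). In this assay this change gave a 1.1-fold higher number from compound 1 to compound 3 (0.06 log units; within the scatter), so compound 1 and compound 3 cannot be told apart on this read-out. Compound 2 is built on a different core; the difference between the core of compound 2 and the core of compound 1 is not broken down here. In this assay compound 2 stands beyond the scatter from both compound 1 and compound 3, with the highest number of the three.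

Compound 4 `CCC1C(=O)N(C)c2cnc(Nc3ccc(S(N)(=O)=O)cc3)nc2N1c1ccn(C)n1` is not yet measured. It stands to compound 2 as compound 3 stands to compound 1: hydrogen in place of butyl on a sulfonamide nitrogen. The place of the change reads the same in both pairs, a sulfonamide nitrogen whose other neighbour is the sulfonyl sulfur, so it is the same change carried onto the core of compound 2. Because the same change from compound 1 to compound 3 gave a 1.1-fold higher number from compound 1 to compound 3 (0.06 log units; within the scatter), the step from compound 2 to compound 4 is expected to be small as well, about a 1.1-fold higher number from compound 2 to compound 4 (0.04 log units; within the scatter). Compound 4 is therefore estimated at 4600 nM in this assay, with a likely span from 2200 nM to 9500 nM. This rests on a single matched pair measured on another core, and a larger deviation on the core of compound 2 cannot be ruled out from the data at hand.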

Compound 4, concentration for 50% growth inhibition: "not active" (no number reported)
Nothing numeric was reported for compound 4; the estimate stays without a comparison.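

In this assay, going by these compounds alone, compound 4 is reported only as not active, with no number, so no step from compound 2 to compound 4 can be read. The compounds shown leave open whether hydrogen in place of butyl on the sulfonamide nitrogen acts differently on the core of compound 2 than on the core of compound 1. No evidence at hand bears on this result.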